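Methyl on the outer phenyl ring of compound 3

The compounds below may be only part of what the source reports. "The series", "measured", "known", "first", "only" and "open" are said of these compounds alone.

The series shares one core and varies only the outer phenyl ring. Compound 1 `CS(=O)(=O)c1ccc(-c2cnc3[nH]cc(-c4nnc(-c5ccc(F)cc5)o4)c(=O)c3c2)cc1` gives 18.7% in a functional assay on HCT-116 cells (Homo sapiens) for inhibition, read by MTT assay, with a stated time of 24 h, tested at 10 uM; on this read-out lower numbers stand for less inhibition of growth and higher numbers for more inhibition of growth at the one concentration tested; compound 2 `Cc1ccc(-c2nnc(-c3c[nH]c4ncc(-c5ccc(S(C)(=O)=O)cc5)cc4c3=O)o2)cc1` gives 24.4%; compound 3 `CS(=O)(=O)c1ccc(-c2cnc3[nH]cc(-c4nnc(-c5ccccc5)o4)c(=O)c3c2)cc1` gives 15.7%. Compound 3 stands at the lowest of the three numbers, but its nearest neighbour is compound 1 with a number 3 percentage points lower from compound 1 to compound 3 (within the scatter) and its furthest is compound 2 with a number 8.7 percentage points lower from compound 2 to compound 3 (within the scatter), so nothing separates the three beyond the scatter, as a number 5.7 percentage points higher from compound 1 to compound 2 (within the scatter) also shows.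

Compound 4 `Cc1cccc(-c2nnc(-c3c[nH]c4ncc(-c5ccc(S(C)(=O)=O)cc5)cc4c3=O)o2)c1` differs from compound 3 by methyl in place of hydrogen on an aromatic carbon, meta to a large group. The step that bears most directly on it is the reverse change of methyl for hydrogen on this ring between compound 2 and compound 3, which stayed within the scatter, though there the methyl sits on another carbon of the same ring. Fluoro for hydrogen or methyl likewise moved nothing beyond the scatter. Compound 4 is therefore expected to show a number 5.3 percentage points higher from compound 3 to compound 4 (within the scatter), no shift beyond the scatter, and an estimated 21% (range 9% to 33%).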

Compound 4, percent growth inhibition at one concentration: 25.2%
Beside the measured number, compound 4's estimate is 4.2 percentage points below it, within the range that was stated.
By their numbers in this assay, from the lowest: compounds 3, 1, 2 and 4 (each within the scatter of the next).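

Phenyl to 3-methylphenyl gives a number 9.5 percentage points higher from compound 3 to compound 4 (within the scatter) in this assay, so methyl on the aromatic carbon meta to a large group produces no shift that can be told from the scatter. The other two comparisons also stay inside it: 3-methylphenyl in place of 4-methylphenyl gives a number 0.8 percentage points higher from compound 2 to compound 4 (within the scatter) and shows no separable effect of this change in methyl placement, while 3-methylphenyl in place of 4-fluorophenyl gives a number 6.5 percentage points higher from compound 1 to compound 4 (within the scatter) and likewise separates nothing. No measurement here bears on why the numbers fall as they do.

As far as these compounds go, the four outer rings carry only hydrogen, fluoro or methyl, so it remains open whether an amine, a carboxylic acid or a longer chain such as butyl on this ring would move the number beyond the scatter. Whether any of these compounds would separate at other concentrations also remains open.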